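This account rests on a few compounds, and the source may have more. Where it says the series, first, only, none or still open, it means among the compounds named here.

Values in a functional assay (trachea) with Cavia porcellus as the target; a higher number here means a weaker inhibitor, a lower number a stronger inhibitor:
- compound 1 `CCCn1nc(-c2cccnc2)c2ccccc2c1=O`: 3160 nM
- compound 2 `O=c1c2ccccc2c(-c2cccnc2)nn1C1CCCC1`: 2750 nM
- compound 3 `CC(=O)OCCn1nc(-c2cccnc2)c2ccccc2c1=O`: 9770 nM

Compound 3 has the highest number of the three. The propyl and cyclopentyl compounds do not separate, with a 1.1-fold lower number from compound 1 to compound 2 (0.06 log units; within the scatter). The acetoxy chain gives modest rises, with a 3.1-fold higher number from compound 1 to compound 3 (0.49 log units; beyond the scatter) and a 3.6-fold higher number from compound 2 to compound 3 (0.55 log units; beyond the scatter).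

Compound 4 `O=C(O)Cn1nc(-c2cccnc2)c2ccccc2c1=O` carries carboxy in place of acetoxymethyl on a saturated chain carbon bound to an aromatic nitrogen. Within the data shown here, no measured step introduces carboxy, so the evidence is indirect. Among the measured compounds shown here, the only guide is the modest size of the steps from compound 1 and compound 2 to compound 3, which suggests a similar modest rise in this assay, held with low confidence.

The expected change is a 2.3-fold higher number from compound 3 to compound 4 (0.35 log units; beyond the scatter). For compound 4 the estimate is 22000 nM, with an expected range of 7000 nM to 70000 nM.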

Compound 4, half-maximal inhibitory concentration: > 100000 nM
Compound 4: only a limit was reported; the forecaster's own chance of this, stated with the estimate: 20%; middle value at least 4.5-fold (0.65 log units) away from the limit.
By their numbers in this assay, from the lowest: compounds 2 and 1 (each within the scatter of the next); then compound 3. At a limit, above all of these: compound 4.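

In this assay compound 4 gives > 100000 nM, which is a limit of the assay and not a number. Among these compounds, on the saturated chain carbon bound to an aromatic nitrogen, carboxy brings the first large steps: an at least 10-fold higher number from compound 3 to compound 4 (1.01 log units; beyond the scatter), an at least 31-fold higher number from compound 1 to compound 4 (1.50 log units; beyond the scatter) and an at least 36-fold higher number from compound 2 to compound 4 (1.56 log units; beyond the scatter). The earlier changes at this place gave modest steps at most, and the true size of these new steps stays unknown: the limit of > 100000 nM in this assay, at which 1 of the 4 values shown sits.

Open, from the compounds shown here alone, is whether a methyl ester or a primary amide at this place would stay close to compound 3. Also open, going by these compounds, is whether a carboxylic acid on a longer chain would return measurable values.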